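The compounds below may be only part of what the source reports. "The series", "measured", "known", "first", "only" and "open" are said of these compounds alone.

Measured so far:
- compound 1, `CCCNCc1nnc(Nc2nc(C)nc3c2c(C)nn3-c2ccc(OC)cc2C)o1`: 996 nM
- compound 2, `CC[C@H](COC)Nc1nc(C)nc2c1c(C)nn2-c1ccc(OC)cc1C`: 210 nM

In a functional assay on CHO cells for antagonist activity at corticotropin-releasing factor receptor 1 (Homo sapiens), read by cAMP accumulation (on this read-out lower numbers stand for stronger inhibition and higher numbers for weaker inhibition), compound 1 gives 996 nM, the highest of the two numbers; its nearest neighbour is compound 2 with 210 nM.

The compound now in question is compound 3, `CCC[C@@H](CO)Nc1nc(C)nc2c1c(C)nn2-c1ccc(OC)cc1C`. It differs from compound 1 in one place: 1-(hydroxymethyl)butyl in place of 5-((propylamino)methyl)-1,3,4-oxadiazol-2-yl on a nitrogen on an aromatic ring. Among the compounds with values here, the only measured step that bears on this change is the one from compound 1 to compound 2, where an open-chain group carrying one oxygen replaced the same ring-containing group on the same nitrogen; that step was a 4.7-fold lower number from compound 1 to compound 2 (0.68 log units; beyond the scatter). The group entering in compound 3 is also a short open chain with one oxygen, so a step of similar direction and size is expected here.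

Compound 3 is therefore expected to give about 250 nM in this assay, with a likely range from 80 nM to 800 nM. This estimate means an expected step of a 4.0-fold lower number from compound 1 to compound 3 (0.60 log units; beyond the scatter).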

Compound 3, inhibition constant: 574 nM
The estimate for compound 3 lay 2.3-fold (0.36 log units) below the measured number, and the stated range covers the measured number.
By their numbers in this assay, from the lowest: compound 2; then compounds 3 and 1 (each within the scatter of the next).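

In this assay, with 1-(hydroxymethyl)butyl in place of 5-((propylamino)methyl)-1,3,4-oxadiazol-2-yl on this nitrogen, the result is a 1.7-fold lower number from compound 1 to compound 3 (0.24 log units; within the scatter), so these two groups cannot be told apart here and an open chain with one oxygen does not by itself give a lower number. The two open chains, however, are not interchangeable at this position: 1-(hydroxymethyl)butyl in place of 1-(methoxymethyl)propyl gives a 2.7-fold higher number from compound 2 to compound 3 (0.44 log units; beyond the scatter), showing that a modest edit within the chain can produce a step beyond the scatter. Nothing available explains this difference between the two chains.

The step between the two chains alters both the main chain, butyl against propyl, and the oxygen end, free hydroxyl against methyl ether, so the compounds shown leave open which of these matters; 1-(methoxymethyl)butyl or 1-(hydroxymethyl)propyl on the same nitrogen would separate the two. Also open, on these data alone, is how a chain with no oxygen, such as a plain pentyl group, would compare at this position.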